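Serine Side Chain on the Purine-Glycine Amide Series

A few compounds are considered here, and "the series" means these few. Any claim that something is new, unique, unknown or untested is made for them only; others in the source may bear on it.

Three compounds sharing one core have been run in a functional assay on the whole organism (Tail, strain ICR) with Mus musculus as the target, in the tail flick test, with a stated time of 30 min, at a dose of 25 umol/kg by the oral route; a lower number here means a weaker effect, a higher number a stronger effect of the compound at the dose given. Compound 1 `C[C@@H](O)[C@H](NC(=O)CN(c1nc(Cl)nc2[nH]cnc12)C1CC1)C(=O)O` gives 18.6%, compound 2 `C[C@H](NC(=O)CN(c1nc(Cl)nc2[nH]cnc12)C1CC1)C(=O)O` gives 48.1%, and compound 3 `CSCC[C@H](NC(=O)CN(c1nc(Cl)nc2[nH]cnc12)C1CC1)C(=O)O` gives 20.4%. Among these three numbers compound 3 stands second highest: its nearest neighbour is compound 1, whose step a number 1.8 percentage points higher from compound 1 to compound 3 (within the scatter) lies within the scatter, while its furthest is compound 2, with a number 27.7 percentage points lower from compound 2 to compound 3 (beyond the scatter) beyond it.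

The unmeasured compound 4 `O=C(CN(c1nc(Cl)nc2[nH]cnc12)C1CC1)N[C@@H](CO)C(=O)O` differs from compound 3 in one place.
hydroxy in place of (methylsulfanyl)methyl on a saturated chain carbon, two bonds along the chain from an amide-type nitrogen and a carbonyl carbon
Cut one bond further out, the same difference reads as 2-(methylsulfanyl)ethyl to hydroxymethyl, which brings compound 4 close to compound 1, where 1-hydroxyethyl occupies that chain carbon. The step bearing most directly on this is a number 1.8 percentage points higher from compound 1 to compound 3 (within the scatter), within the scatter, so exchanging the sulfur-bearing chain for an oxygen-bearing one has so far not moved this assay. The larger step of a number 27.7 percentage points lower from compound 2 to compound 3 (beyond the scatter) concerns hydrogen at that carbon and does not apply here.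

Compound 4 is therefore expected to sit near compound 3, with an estimated step of a number 1.6 percentage points higher from compound 3 to compound 4 (within the scatter) that stays within the scatter. For compound 4 the estimate in this assay is 22%, with a range from 8% to 40%.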

Compound 4, a percentage reported as activity, at one dose (the size of the read-out at that dose, not a potency): 38.7%
Compound 4: the middle estimate sits 16.7 percentage points below what was measured; the measured number falls inside the stated range.
By their numbers in this assay, from the lowest: compounds 1 and 3 (each within the scatter of the next); then compounds 4 and 2 (each within the scatter of the next).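

In this assay, the sulfur-bearing chain and an oxygen-bearing chain had looked alike while the oxygen-bearing chain was 1-hydroxyethyl, but hydroxymethyl separates from 2-(methylsulfanyl)ethyl (a number 18.3 percentage points higher from compound 3 to compound 4 (beyond the scatter)), so the earlier match does not extend to every oxygen-bearing chain at this carbon. The sharpest new finding is that removing only the methyl from the 1-hydroxyethyl chain of compound 1 is enough to change the read-out (a number 20.1 percentage points higher from compound 1 to compound 4 (beyond the scatter)), whereas hydroxy in place of hydrogen on the methyl chain of compound 2 leaves it within the scatter (a number 9.4 percentage points lower from compound 2 to compound 4 (within the scatter)), so the hydroxy group by itself does not separate these two compounds. No measurement available here accounts for these differences.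

The compounds shown leave open whether the read-out stays at this level with an amine in place of the hydroxy of hydroxymethyl, or falls with a longer chain such as 2-hydroxyethyl. They also leave open what a carboxylic acid on this chain would do, and whether a 2-(methylsulfanyl)ethyl chain shortened to (methylsulfanyl)methyl would follow compound 4 or compound 3.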